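A few compounds are considered here, and "the series" means these few. Any claim that something is new, unique, unknown or untested is made for them only; others in the source may bear on it.

Measured in an assay for inhibition of Rho-associated protein kinase 1 (Homo sapiens), read by TR-FRET, with stated times of 5 min and 2 h; a higher number here means a weaker inhibitor, a lower number a stronger inhibitor: compound 1 `CC1(C)NC(=O)c2sc(-c3ccncc3)cc2N1` gives 90 nM; compound 2 `CC(C)C1(C)NC(=O)c2sc(-c3ccncc3)cc2N1` gives 35 nM; compound 3 `CC1(CC(F)(F)F)NC(=O)c2sc(-c3ccncc3)cc2N1` gives 31 nM.

Compound 1 gives the highest number of the three in this assay; the others sit a 2.6-fold lower number from compound 1 to compound 2 (0.41 log units; beyond the scatter) and a 2.9-fold lower number from compound 1 to compound 3 (0.46 log units; beyond the scatter). Compound 4 `CC1(C)Nc2cc(-c3ccncc3)sc2C(=O)N1Cc1ccccc1` differs from compound 1 by benzyl in place of hydrogen on an amide-type nitrogen in a ring. For the measured compounds named here, both measured steps from compound 1 change the substituent on the saturated ring carbon, and the pair of the larger groups is a 1.1-fold lower number from compound 2 to compound 3 (0.05 log units; within the scatter); none of these steps touches the amide-type nitrogen, so no measured step bears directly on this change. Without a precedent, compound 4 is estimated at 200 nM with a range of 50 nM to 1500 nM. This estimate implies a step of a 2.2-fold higher number from compound 1 to compound 4 (0.35 log units; beyond the scatter).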

Compound 4, half-maximal inhibitory concentration: 1.5 nM
Estimate against measurement, compound 4: 130-fold (2.12 log units) above; the whole stated range lies above it.
By their numbers in this assay, from the lowest: compound 4; then compounds 3 and 2 (each within the scatter of the next); then compound 1.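

For the compounds shown here, the amide-type nitrogen in the ring, untouched by the earlier steps, accepts a benzyl group, and in this assay this single change gives a 60-fold lower number from compound 1 to compound 4 (1.78 log units; beyond the scatter). That step is far larger than a 2.6-fold lower number from compound 1 to compound 2 (0.41 log units; beyond the scatter) or a 2.9-fold lower number from compound 1 to compound 3 (0.46 log units; beyond the scatter), so among the compounds shown, this nitrogen is the more sensitive place. No data given here explain the gain.

Going by these compounds, whether the aromatic ring of the benzyl is needed stays open, since an ethyl or a longer phenylalkyl chain on this nitrogen would be required to tell. Also open, on these data alone, is whether the gain would hold alongside isopropyl or 2,2,2-trifluoroethyl on the saturated ring carbon.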